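The compounds below may be only part of what the source reports. "The series", "measured", "known", "first", "only" and "open" are said of these compounds alone.

Of the compounds shown here, three sharing one core have been measured in a functional assay for agonist activity at Free fatty acid receptor 1 (Homo sapiens), read by FLIPR, in the presence of a further agent that is not named here; on this read-out higher numbers stand for an effect only at larger amounts of compound and lower numbers for an effect already at smaller amounts. Compound 3 `Cc1cccc(Oc2ccc(CC3SC(=O)NC3=O)cc2)c1` gives 203 nM, compound 1 `Cc1ccc(C)c(Oc2ccc(CC3SC(=O)NC3=O)cc2)c1` gives 238 nM, and compound 2 `Cc1cccc(Oc2ccc(CC3SC(=O)NC3=O)cc2)n1` gives 2620 nM. Compound 3 has the lowest number of the three, but its gap to compound 1 is small: a 1.2-fold lower number from compound 1 to compound 3 (0.07 log units; within the scatter). The step from compound 2 is large, a 13-fold lower number from compound 2 to compound 3 (1.11 log units; beyond the scatter).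

Compound 4 `Cc1ccc(Oc2ccc(CC3SC(=O)NC3=O)cc2)cc1C` has not yet been measured. It differs from compound 3 in one place: methyl in place of hydrogen on an aromatic carbon, on an aromatic carbon of a six-membered aromatic ring of carbon only, ortho to a methyl group and para to a large group.

For the measured compounds named here, the step that bears on this is the one from compound 1 to compound 3, where a methyl was also removed from an aromatic carbon and the number barely moved. On that basis compound 4 is expected to behave much like compound 3, with a step of about a 1.1-fold higher number from compound 3 to compound 4 (0.03 log units; within the scatter), which would fall within the usual scatter. Compound 4 is therefore estimated at 220 nM, with a range from 100 nM to 500 nM.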

Compound 4, half-maximal effective concentration: 727 nM
The estimate for compound 4 lay 3.3-fold (0.52 log units) below the measured number, outside the stated range (above it).
By their numbers in this assay, from the lowest: compounds 3 and 1 (each within the scatter of the next); then compound 4; then compound 2.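

In this assay, a methyl on the aromatic carbon ortho to a methyl group and para to a large group is not a neutral addition: a 3.6-fold higher number from compound 3 to compound 4 (0.55 log units; beyond the scatter) is a modest step beyond the scatter. The methyl that separates compound 1 from compound 3 sits on a different carbon of the same ring, and a 1.2-fold lower number from compound 1 to compound 3 (0.07 log units; within the scatter) stays within the scatter, so in these compounds the effect of a methyl depends on the carbon that carries it. Nothing measured here explains why this carbon behaves differently.

Going by these compounds, whether an ethyl, a methoxy group or a fluorine on this carbon would shift the number further, less or the other way remains open. Also open, on these data alone, is whether the new methyl would give a similar step if the methyl group ortho to it were absent.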